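The source may hold more compounds than are shown below. What is called first, only, known or untested is meant among the compounds shown, and "the series" means these compounds.

Measured so far in an ADME assay on the whole organism (Mus musculus, strain CD1) for pharmacokinetics, read by LC-MS, using cassette dosing, with a stated time of 24 h, at a dose of 0.4 mg/kg by the intravenous route; a lower number here means slower removal, a higher number faster removal of the compound:
compound 3 `Cc1cn(-c2cc(NC(=O)c3ccc(C)c(Oc4ccccc4)c3)cc(C(F)(F)F)c2)cn1` gives 12.5 mL/min/kg;
compound 1 `Cc1cn(-c2cc(CN3CCN(C)CC3)cc(NC(=O)c3ccc(C)c(Nc4nccc(-c5ccccc5)n4)c3)c2)cn1` gives 35.7 mL/min/kg;
compound 2 `Cc1cn(-c2cc(CCS(N)(=O)=O)cc(NC(=O)c3ccc(C)c(Nc4nccc(-c5ccccc5)n4)c3)c2)cn1` gives 110 mL/min/kg.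

Compound 3 stands lowest of the three numbers, with compound 1 nearest and compound 2 furthest. Among the measured compounds shown here, the only single-point step measured is a 3.1-fold higher number from compound 1 to compound 2 (0.49 log units; beyond the scatter), which does not touch the change considered here. Compound 4 `Cc1cn(-c2cc(NC(=O)c3ccc(C)c(Oc4ccccc4)c3)cc(N3CCN(C)CC3)c2)cn1` differs from compound 3 by 4-methylpiperazin-1-yl in place of trifluoromethyl on an aromatic carbon. For the measured compounds named here, no measured step covers this exact change; compound 1, which carries the same piperazine ring on a chain carbon at that position but a different amide side, gives 35.7 mL/min/kg against 12.5 mL/min/kg for compound 3. On that basis a modest rise is expected, a 2.4-fold higher number from compound 3 to compound 4 (0.38 log units; beyond the scatter), with wide uncertainty. Compound 4 is estimated at 30 mL/min/kg, within 12 mL/min/kg to 75 mL/min/kg.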

Compound 4, clearance: 17.5 mL/min/kg
The estimate for compound 4 lay 1.7-fold (0.23 log units) above the measured number; the range from low to high includes it.
By their numbers in this assay, from the lowest: compounds 3 and 4 (each within the scatter of the next); then compound 1; then compound 2.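

In this assay, 4-methylpiperazin-1-yl in place of trifluoromethyl on an aromatic carbon leaves the reading within the usual scatter (a 1.4-fold higher number from compound 3 to compound 4 (0.15 log units; within the scatter)). At this place on the shared core, meta to a 4-methyl-1H-imidazol-1-yl group, clearance therefore does not separate the two groups, although the entering group adds a six-membered non-aromatic ring and more heavy atoms. Open, going by these compounds, is whether a morpholine ring or a carboxylic acid on this aromatic carbon, or 4-methylpiperazin-1-yl on a saturated chain carbon, would read alike on this core. No measured evidence bears on this result.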